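The source may hold more compounds than are shown below. What is called first, only, known or untested is meant among the compounds shown, and "the series" means these compounds.

Working notes on the series. Compound 1 `COc1ccc(-c2cc(/C=C/C(=O)c3ccc(N)cc3)[nH]n2)cc1` and compound 2 `COc1ccc(-c2cc(/C=C/C(=O)c3ccc(N)cc3)[nH]n2)cc1OC` share a core; in a functional assay on MDA-MB-231 cells (Homo sapiens) for inhibition, read by sulforhodamine B assay, with a stated time of 48 h (on this read-out higher numbers stand for weaker inhibition of growth and lower numbers for stronger inhibition of growth), compound 1 gives 8290 nM and compound 2 gives 17200 nM. The change hydrogen in place of methoxy on an aromatic carbon made a 2.1-fold lower number from compound 2 to compound 1 (0.32 log units; beyond the scatter). Compound 3 `COc1cc(C(=O)/C=C/c2cc(-c3cc(OC)c(OC)c(OC)c3)n[nH]2)cc(OC)c1OC` has a different core; in this assay compound 3 gives 3800 nM, the lowest of the three numbers, with compound 1 nearest and compound 2 furthest. How the core of compound 3 differs from the core of compound 2 is not broken down here. Compound 4 `COc1ccc(-c2cc(/C=C/C(=O)c3cc(OC)c(OC)c(OC)c3)[nH]n2)cc1OC` is not yet measured. It differs from compound 3 by hydrogen in place of methoxy on an aromatic carbon, the same kind of change as that from compound 2 to compound 1, though here the place is also meta to a methoxy group. In this assay, among the measured compounds shown here, the number for compound 4 is expected to move from compound 3 by a 1.7-fold lower number from compound 3 to compound 4 (0.24 log units; within the scatter), which rests on the single earlier step of a 2.1-fold lower number from compound 2 to compound 1 (0.32 log units; beyond the scatter) and carries the uncertainty of one precedent. The estimate for compound 4 in this assay is 2200 nM, expected to fall between 900 nM and 6000 nM.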

Compound 4, concentration for total growth inhibition: 13500 nM
Estimate against measurement, compound 4: 6.1-fold (0.79 log units) below; measured number above the stated range.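

Hydrogen in place of methoxy on an aromatic carbon gave a 3.6-fold higher number from compound 3 to compound 4 (0.55 log units; beyond the scatter) in this assay, so on this core the number moved in the opposite direction from the earlier step on the core of compound 1 and compound 2. The two steps differ by more than their scatter allows: the same change on two cores in this assay, a 2.1-fold lower number (0.32 log units; beyond the scatter) from compound 2 to compound 1 and a 3.6-fold higher number (0.55 log units; beyond the scatter) from compound 3 to compound 4, 7.4-fold (0.87 log units) apart, beyond the scatter of two such steps

In this series, a step measured on one core therefore cannot simply be carried to the other, although the two pairs alone do not show which difference between the cores decides the direction or yield a general rule.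

The compounds shown leave open whether a hydroxyl group or a chlorine atom in place of that methoxy group would follow either step. Also open, on these data alone, is whether removing one of the other methoxy groups of compound 3 would move the number in the same direction.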